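The compounds below may be only part of what the source reports. "The series", "measured", "known", "first", "only" and "open" are said of these compounds alone.

Measured in a physicochemical assay for solubility, read by chemiluminescence; a higher number here means a more soluble compound, a lower number a less soluble compound:
- compound 1 `O=C(CN(CC1CC1)C(=O)c1ccc(-c2ccccn2)cc1)Nc1cc(F)cc(F)c1` gives 25 ug/mL
- compound 2 `O=C(CN(CC1CCC1)C(=O)c1ccc(-c2ccccn2)cc1)Nc1cc(F)cc(F)c1` gives 7 ug/mL
- compound 3 `COCC(C)N(CC(=O)Nc1cc(F)cc(F)c1)C(=O)c1ccc(-c2ccccn2)cc1` gives 58 ug/mL

Compound 3 has the highest number of the three, and both steps to it lie beyond the scatter: a 2.3-fold higher number from compound 1 to compound 3 (0.37 log units; beyond the scatter) and an 8.3-fold higher number from compound 2 to compound 3 (0.92 log units; beyond the scatter).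

Compound 4 `CCC(COC)N(CC(=O)Nc1cc(F)cc(F)c1)C(=O)c1ccc(-c2ccccn2)cc1` differs from it by one change: methyl in place of hydrogen on a saturated chain carbon, two bonds along the chain from an amide-type nitrogen. This is methyl in place of hydrogen on a saturated chain carbon, two bonds along the chain from an amide-type nitrogen, turning 1-(methoxymethyl)ethyl into 1-(methoxymethyl)propyl.

Among the compounds with values here, no measured step makes this exact change. The closest is a 3.6-fold lower number from compound 1 to compound 2 (0.55 log units; beyond the scatter), where cyclobutyl replaces cyclopropyl and the group on that nitrogen also grows. The two steps to compound 3 swap whole groups and bear on it only loosely. That single precedent points to a modest fall in this assay, and the evidence for it is thin.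

The estimated step is a 2.3-fold lower number from compound 3 to compound 4 (0.37 log units; beyond the scatter). The estimate for compound 4 is 25 ug/mL, with an expected range of 10 ug/mL to 60 ug/mL.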

Compound 4, solubility: 24 ug/mL
For compound 4 the middle estimate is 1.0-fold (0.02 log units) above the measured one; the measured number falls inside the stated range.
By their numbers in this assay, from the lowest: compound 2; then compounds 4 and 1 (each within the scatter of the next); then compound 3.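

In this assay, within the data shown here, the methyl on the saturated chain carbon, two bonds along the chain from the amide-type nitrogen, gives the first one-place reading at this position, and even this single added carbon counts (a 2.4-fold lower number from compound 3 to compound 4 (0.38 log units; beyond the scatter)). The lead of 1-(methoxymethyl)ethyl over cyclopropylmethyl is lost in 1-(methoxymethyl)propyl (a 1.0-fold lower number from compound 1 to compound 4 (0.02 log units; within the scatter)), yet 1-(methoxymethyl)propyl still stands clear of cyclobutylmethyl (a 3.4-fold higher number from compound 2 to compound 4 (0.54 log units; beyond the scatter)). No measurement at hand explains the fall.

As far as these compounds go, whether a longer chain at this carbon lowers the number further, or a hydroxyl or an amine in place of the methyl reverses the step, remains open. From the compounds shown here alone, this position rests on one pair, so it also remains open whether the methyl would give a similar step with another group on the amide-type nitrogen.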